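Chalcone-triazole series: HeLa inhibition, notes on a pending analogue

The source may hold more compounds than are shown below. What is called first, only, known or untested is meant among the compounds shown, and "the series" means these compounds.

Measured so far:
compound 1 `CCCCCCCCn1cc(/C=C/C(=O)c2ccc(NC(=O)CN3CCN(c4ccccc4F)CC3)cc2)nn1`: 33800 nM
compound 2 `O=C(CN1CCN(c2ccccc2F)CC1)Nc1ccc(C(=O)/C=C/c2cn(Cc3ccc(Br)cc3)nn2)cc1`: 9120 nM
compound 3 `CCCCCCCCn1cc(/C=C/C(=O)c2ccc(NC(=O)CN3CCN(c4ccc([N+](=O)[O-])cc4)CC3)cc2)nn1`: 30200 nM

In a functional assay on HeLa cells (Homo sapiens) for inhibition, read by MTT assay (on this read-out higher numbers stand for weaker inhibition and lower numbers for stronger inhibition), compound 1 gives 33800 nM and compound 3 gives 30200 nM. The two differ only by 4-nitrophenyl in place of 2-fluorophenyl on an amine nitrogen in a ring, and in this assay the step is a 1.1-fold lower number from compound 1 to compound 3 (0.05 log units; within the scatter), so these two cores give indistinguishable numbers here. Compound 2 carries 4-bromophenyl in place of heptyl on a saturated chain carbon bound to an aromatic nitrogen relative to compound 1, and in this assay this gives a 3.7-fold lower number from compound 1 to compound 2 (0.57 log units; beyond the scatter).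

Compound 4 `O=C(CN1CCN(c2ccc([N+](=O)[O-])cc2)CC1)Nc1ccc(C(=O)/C=C/c2cn(Cc3ccc(Br)cc3)nn2)cc1` has not yet been measured in this assay. Among the measured compounds shown here, it differs from compound 3 by 4-bromophenyl in place of heptyl on a saturated chain carbon bound to an aromatic nitrogen, the same change as the one from compound 1 to compound 2, at the same place, on the other core. Since that core change in compound 3 left the number essentially where compound 1 stands, the expectation is that the change made on compound 3 behaves as it did on compound 1. For compound 4 the expected step in this assay is a 3.7-fold lower number from compound 3 to compound 4 (0.57 log units; beyond the scatter), resting on compound 3 at 30200 nM and the earlier step of a 3.7-fold lower number from compound 1 to compound 2 (0.57 log units; beyond the scatter). Compound 4 is estimated at 8200 nM, with a range from 3500 nM to 20000 nM expected.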

Compound 4, half-maximal inhibitory concentration: 26600 nM
Compound 4: middle estimate off by 3.2-fold (0.51 log units), on the low side; the whole stated range lies below it.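

On the core of compound 3, 4-bromophenyl in place of heptyl gives a 1.1-fold lower number from compound 3 to compound 4 (0.06 log units; within the scatter) in this assay, so the step seen on the core of compound 1 does not carry over: the same change on two cores in this assay, a 3.7-fold lower number (0.57 log units; beyond the scatter) from compound 1 to compound 2 and a 1.1-fold lower number (0.06 log units; within the scatter) from compound 3 to compound 4, 3.3-fold (0.51 log units) apart, beyond the scatter of two such steps

Read the other way, 4-nitrophenyl in place of 2-fluorophenyl gives a 2.9-fold higher number from compound 2 to compound 4 (0.46 log units; beyond the scatter), so this change also depends on the core it is made on: the same change on two cores in this assay, a 1.1-fold lower number (0.05 log units; within the scatter) from compound 1 to compound 3 and a 2.9-fold higher number (0.46 log units; beyond the scatter) from compound 2 to compound 4, 3.3-fold (0.51 log units) apart, beyond the scatter of two such steps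

The two changes therefore do not add up in these four compounds, and the lower number appears only in compound 2, where 4-bromophenyl and 2-fluorophenyl stand together; the data do not show why this is so, or whether it holds for any other pair of groups or beyond this one cell line.

On these data alone, it remains open whether this dependence is specific to 4-bromophenyl and 2-fluorophenyl. An unsubstituted phenyl on the amine nitrogen in the ring, or butyl in place of heptyl on the chain, would test how far it extends.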